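This account rests on a few compounds, and the source may have more. Where it says the series, first, only, none or still open, it means among the compounds named here.

Compound 1 `COc1ccc(/C=C/[C@@](C)(/C=C/c2ccc(O)cc2)CCC=C(C)C)cc1`: > 36600 nM
Compound 2 `CC(C)=CCC[C@@](C)(/C=C/c1ccccc1)/C=C/c1ccc(O)cc1`: > 36600 nM
Compound 3 `CC(C)=CCC[C@@](C)(/C=C/c1ccc(C)cc1)/C=C/c1ccc(O)cc1`: > 36600 nM

In an ADME assay on BJ cells (Homo sapiens) for cytotoxicity, with a stated time of 72 h (on this read-out higher numbers stand for an effect only at larger amounts of compound and lower numbers for an effect already at smaller amounts), compound 3 gives > 36600 nM, which is a limit of the assay and not a number. Compound 1, compound 2 and compound 3 all share (the limit of > 36600 nM in this assay, at which 3 of the 3 values shown sit). Compound 4 `CC(C)=CCC[C@](C)(/C=C/c1ccc(O)cc1)/C=C/c1ccc(C#N)cc1` carries cyano in place of methyl on an aromatic carbon. Three measured steps also change a group on an aromatic carbon: a step that the two limits leave unreadable from compound 1 to compound 2, a step that the two limits leave unreadable from compound 1 to compound 3 and a step that the two limits leave unreadable from compound 2 to compound 3. None of them gives a size, so the evidence is thin, but none points to a change in this assay. The expected outcome is a number no higher from compound 3 to compound 4 (the limit leaves the size open), with nothing beyond the scatter. For compound 4 the estimate is 36600 nM, with an expected range of 15000 nM to 60000 nM.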

Compound 4, half-maximal effective concentration: > 36600 nM
Compound 4 was reported as a limit; the forecaster's own chance of this, stated with the estimate: 85%; the middle value lies on the limit itself.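

No step among compound 1, compound 2, compound 3 and compound 4 can be read in this assay, because all four values are limits and not numbers: the limit of > 36600 nM in this assay, at which 4 of the 4 values shown sit.

The compounds shown leave open what amount of any of them, if any, would harm these cells.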